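The source may report more compounds than this note shows. Statements on the series, on what has been measured and on what is new or still open speak of the compounds shown alone.

Compound 1, `Cc1ccc(S(=O)(=O)N(C)CC(C)C)cc1C#Cc1cc(Cl)ccc1OCC(=O)O`: in an in vitro ADME assay on microsomes from liver (Homo sapiens) for metabolic stability, read by LC-MS, tested at 1 uM (on this read-out lower numbers stand for slow clearance and higher numbers for fast clearance), compound 1 gives 79 mL.min-1.g-1.
Compound 2, `Cc1ccc(S(=O)(=O)NC(C)C)cc1C#Cc1cc(Cl)ccc1OCC(=O)O`: in this assay compound 2 gives < 10 mL.min-1.g-1, which is a limit of the assay.
Compound 3, `COCCNS(=O)(=O)c1ccc(C)c(C#Cc2cc(Cl)ccc2OCC(=O)O)c1`: in this assay compound 3 gives < 10 mL.min-1.g-1, again a limit of the assay.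

Compound 3 therefore sits at the low end of what the assay can report, together with one other compound, as the limit of < 10 mL.min-1.g-1 in this assay, at which 2 of the 3 values shown sit, shows. Compound 4, `Cc1ccc(S(C)(=O)=O)cc1C#Cc1cc(Cl)ccc1OCC(=O)O`, differs from it only in one place: methyl in place of (2-methoxyethyl)amino on a sulfonyl sulfur. Within the data shown here, two measured steps touch this position. The step of an at least 7.9-fold lower number from compound 1 to compound 3 (0.89 log units; beyond the scatter) shows that trimming the group on the sulfonyl sulfur went hand in hand with a large drop, while the step that the two limits leave unreadable from compound 2 to compound 3 cannot be read because both ends are limits. Compound 4 is expected to stay near the limit, with an estimated step that the limit leaves unreadable from compound 3 to compound 4 that is not beyond the scatter. The estimate for compound 4 is 8 mL.min-1.g-1, within 3 mL.min-1.g-1 to 25 mL.min-1.g-1.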

Compound 4, intrinsic clearance in microsomes: 14 mL.min-1.g-1
Estimate against measurement, compound 4: 1.8-fold (0.24 log units) below, and the stated range covers the measured number.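

Compound 4 shows that a methyl, with no hydrogen-bond donor, can replace the nitrogen-linked groups on the sulfonyl sulfur and still stay well clear of compound 1: a 5.6-fold lower number from compound 1 to compound 4 (0.75 log units; beyond the scatter). In this assay, the comparisons with the two limit compounds read an at least 1.4-fold higher number from compound 3 to compound 4 (0.14 log units; that floor lies within the scatter) and an at least 1.4-fold higher number from compound 2 to compound 4 (0.14 log units; that floor lies within the scatter), so neither establishes a real rise. The true size of these two steps stays unknown: the limit of < 10 mL.min-1.g-1 in this assay, at which 2 of the 4 values shown sit.

Still open, from the compounds shown here alone, is whether the high number of compound 1 follows its isobutyl part or the methyl on its nitrogen. An isobutylamino or a dimethylamino group on the sulfonyl sulfur would separate the two.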